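Swapping the Sulfonyl Aryl Group of Compound 2

The source may hold more compounds than are shown below. What is called first, only, known or untested is meant among the compounds shown, and "the series" means these compounds.

Measured in a functional assay on HL-60 cells (Homo sapiens) for inhibition, read by CCK-8 assay, with a stated time of 48 h, tested at 20 uM; on this read-out higher numbers stand for more inhibition of growth at the one concentration tested and lower numbers for less inhibition of growth:
Compound 1 `N#C/C(=C\c1ccccc1OS(=O)(=O)c1ccc(F)cc1)C(=O)Nc1nnc(Cc2ccccc2)s1`: 22%
Compound 2 `Cc1ccc(Cc2nnc(NC(=O)/C(C#N)=C/c3ccccc3OS(=O)(=O)c3ccccc3[N+](=O)[O-])s2)cc1`: 33%

Of these two compounds, compound 2 stands higher at 33%, and the gap down to compound 1 lies beyond the usual scatter. The next compound to consider is compound 3 `Cc1ccc(Cc2nnc(NC(=O)/C(C#N)=C/c3ccccc3OS(=O)(=O)c3ccc(F)cc3)s2)cc1`, which has not yet been measured. It differs from compound 2 in one place: 4-fluorophenyl in place of 2-nitrophenyl on a sulfonyl sulfur. Put simply, 4-fluorophenyl sits in place of 2-nitrophenyl on a sulfonyl sulfur.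

Among the compounds with values here, no measured pair shows this change on its own, so its size cannot be read directly from the data. Within the data shown here, the only guide is compound 1, which also carries 4-fluorophenyl on its sulfonyl sulfur and gives 22%. That guide is imperfect, since compound 1 and compound 2 differ in more than one place. A small fall that stays within the scatter is therefore expected, and the estimated step is a number 7 percentage points lower from compound 2 to compound 3 (within the scatter). The estimated value for compound 3 is 26%, with an expected range of 14% to 40%.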

Compound 3, percent growth inhibition at one concentration: 11%
Compound 3: the middle estimate sits 15 percentage points above what was measured, and the stated range ends above it.
By their numbers in this assay, from the lowest: compound 3; then compound 1; then compound 2.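

In this assay, the sulfonyl aryl group can now be read alone. Here, 4-fluorophenyl in place of 2-nitrophenyl on a sulfonyl sulfur gives a number 22 percentage points lower from compound 2 to compound 3 (beyond the scatter). The methyl can now also be read alone, which compound 1 and compound 2 did not allow because they differ in more than one place: methyl in place of hydrogen on an aromatic carbon gives a number 11 percentage points lower from compound 1 to compound 3 (beyond the scatter) when 4-fluorophenyl is on the sulfonyl sulfur. Nothing measured on these compounds explains either step.

Still open, as far as these compounds go, is whether the same methyl change would move the number in the same direction with 2-nitrophenyl on the sulfonyl sulfur, and whether ethyl in its place would behave like the methyl. Also open, from the compounds shown here alone, is how plain phenyl, or a phenyl carrying an amine or a carboxylic acid, would compare with 2-nitrophenyl and 4-fluorophenyl on the sulfonyl sulfur.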